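A few compounds are considered here, and "the series" means these few. Any claim that something is new, unique, unknown or untested is made for them only; others in the source may bear on it.

Working notes on the series. Compound 1 `CCCCCCOc1ccc2c(=O)c(-c3ccc(O)cc3)coc2c1` gives 1500 nM in an assay (Cricetulus griseus) for inhibition of aldehyde dehydrogenase, mitochondrial (Homo sapiens); a lower number here means a stronger inhibitor, a higher number a weaker inhibitor; compound 2 `C=CCCCCOc1ccc2c(=O)c(-c3ccc(O)cc3)coc2c1` gives 150 nM and stands lowest of the two. Within the data shown here, the single step measured, a 10-fold lower number from compound 1 to compound 2 (1.00 log units; beyond the scatter), is the only guide. Compound 3 `CC(C)Oc1ccc2c(=O)c(-c3ccc(O)cc3)coc2c1` differs from compound 2 by isopropyl in place of hex-5-en-1-yl on an oxygen on an aromatic ring: the terminal vinyl and most of the chain are gone, so the gain seen from compound 1 to compound 2 is not expected to carry over. The expected step is a 17-fold higher number from compound 2 to compound 3 (1.22 log units; beyond the scatter), a move back to the region of compound 1 or somewhat beyond it. For compound 3 the estimate is 2500 nM, within 600 nM to 10000 nM.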

Compound 3, half-maximal inhibitory concentration: 80 nM
For compound 3 the middle estimate is 31-fold (1.49 log units) above the measured one; the measured number lies below the stated range.
By their numbers in this assay, from the lowest: compounds 3 and 2 (each within the scatter of the next); then compound 1.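

The terminal vinyl is not needed for a low number in this assay at this position, on an oxygen on an aromatic ring: isopropyl in place of hexyl gives (a 19-fold lower number from compound 1 to compound 3 (1.27 log units; beyond the scatter)). Isopropyl in place of hex-5-en-1-yl gives (a 1.9-fold lower number from compound 2 to compound 3 (0.27 log units; within the scatter)), so these two groups are not separated here, although one is a branched group of 3 carbons and the other a chain of 6 carbons with a double bond. No supporting data bear on why this is so.

As far as these compounds go, how a cyclopentyl group, or a chain ending in an amine or a carboxylic acid, would read on this oxygen remains open.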